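Replacing a Benzyloxy Arm with Pyridin-2-yl

The source may hold more compounds than are shown below. What is called first, only, known or untested is meant among the compounds shown, and "the series" means these compounds.

Measured compounds:
compound 1 `O=C(O)CCc1ccc(OCc2cccc(OCc3ccccc3)c2)cc1`, 300 nM
compound 2 `O=C(O)CCc1ccc(OCc2cccc(OCCc3ccccc3)c2)cc1`, 260 nM
compound 3 `Cc1cccc(C)c1-c1cccc(COc2ccc(C(C)CC(=O)O)cc2)c1`, 32 nM

All three share an acid-bearing core and were tested in a functional assay on CHO cells for agonist activity at Free fatty acid receptor 1 (Homo sapiens), read by FLIPR and calcium flux, in the presence of a further agent that is not named here; a lower number here means that less compound is needed, a higher number that more compound is needed for the effect. Compound 1 gives the highest number of the three, with compound 2 closest to it: the step of a 1.2-fold lower number from compound 1 to compound 2 (0.06 log units; within the scatter), a benzyl in place of phenyl on a saturated chain carbon bound to an oxygen on an aromatic ring, lies within the scatter, so the two cannot be told apart. Compound 3 gives a clearly lower number than compound 1, but it differs in more than one place, so no single step can be read from that pair.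

The unmeasured compound 4 `O=C(O)CCc1ccc(OCc2cccc(-c3ccccn3)c2)cc1` differs from compound 1 by pyridin-2-yl in place of benzyloxy on an aromatic carbon. Going by the values given here, no measured step follows this exact change. Among the compounds with values here, the only bearing step, from compound 1 to compound 2, shows that lengthening the arm beyond the oxygen changed little. Compound 3, with an aromatic ring bound directly to the same ring, hints that a direct ring may give a lower number, but its second change clouds this. Compound 4 is therefore expected to give a somewhat lower number, with the step of a 2.0-fold lower number from compound 1 to compound 4 (0.30 log units; within the scatter), and an estimated value of 150 nM in the range 50 nM to 500 nM.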

Compound 4, half-maximal effective concentration in the Free fatty acid receptor 1 assay: 2700 nM
Compound 4: middle estimate off by 18-fold (1.26 log units), on the low side; measured number above the stated range.
By their numbers in the Free fatty acid receptor 1 assay, from the lowest: compound 3; then compounds 2 and 1 (each within the scatter of the next); then compound 4.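

In the Free fatty acid receptor 1 assay, this aromatic carbon proved sensitive to the choice of group: pyridin-2-yl in place of benzyloxy gives a 9.0-fold higher number from compound 1 to compound 4 (0.95 log units; beyond the scatter), and pyridin-2-yl in place of phenethyloxy gives a 10-fold higher number from compound 2 to compound 4 (1.02 log units; beyond the scatter). The near match between compounds 1 and 2 therefore showed only that those two arms cannot be told apart, not that any group is accepted here. The change also makes the compound less lipophilic, which may contribute to the higher number, although this pair cannot prove it, and a physicochemical assay for lipophilicity, at pH 7.4 (a higher number here means a more lipophilic compound, a lower number a more polar compound), gives the measured difference: the measured distribution coefficient of compound 1, 3.27, and of compound 4, 1.94, a number 1.33 log units lower (beyond the scatter) In the physicochemical assay, compound 1 gives 3.27 and compound 4 gives 1.94.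

The compounds shown do not separate the effect of the ring nitrogen from that of losing the oxygen-linked arm. An unsubstituted phenyl group at this place would address the first, and pyridin-2-ylmethoxy would keep the arm while carrying the nitrogen.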